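An isoquinolin-5-yl swap on compound 1

The compounds below may be only part of what the source reports. "The series", "measured", "known", "first", "only" and "open" are said of these compounds alone.

In a functional assay on A-375 cells (Homo sapiens) for inhibition, read by sulforhodamine B assay, with a stated time of 6 days (a lower number here means a stronger inhibitor, a higher number a weaker inhibitor), compound 1 (`CNCCNCc1cccc(-c2nc(NC3CCOCC3)c(C)c(-c3cn(C)nc3C)n2)c1`) gives > 50000 nM as its reading, which is a limit and not a number. Compound 2 (`CNCCNCc1cccc(-c2nc(Nc3ccccc3)c(C)c(-c3c(C)nn(C)c3C)n2)c1`) gives 6700 nM as a true number in this assay on the same shared core. Compound 3 (`CNCCNCc1cccc(-c2nc(NC3CCOCC3)c(C)c(-c3cccc4cnccc34)n2)c1`) carries isoquinolin-5-yl in place of 1,3-dimethyl-1H-pyrazol-4-yl on an aromatic carbon. No measured single change guides the size of this step. Compound 2 at 6700 nM shows that a number can be reached here, so a moderate gain beyond the scatter is expected. The estimated step is an at least 4.1-fold lower number from compound 1 to compound 3 (0.61 log units; beyond the scatter) toward stronger inhibition. Compound 3 is estimated at 12000 nM with an expected range from 2500 nM to 50000 nM for now.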

Compound 3, half-maximal inhibitory concentration: 12700 nM
Estimate against measurement, compound 3: 1.1-fold (0.02 log units) below; low and high end bracket the measured number.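

In this assay, isoquinolin-5-yl in place of 1,3-dimethyl-1H-pyrazol-4-yl gives an at least 3.9-fold lower number from compound 1 to compound 3 (0.59 log units; beyond the scatter). So with the (oxan-4-yl)amino group kept, the group at this aromatic carbon alone is enough to move the reading from a limit to a true number. The real size of the step stays unknown because compound 1 reads only as a limit: the limit of > 50000 nM in this assay, at which 1 of the 3 values shown sits.

From the compounds shown here alone, it remains open whether the carbon-only ring of isoquinolin-5-yl or its ring nitrogen matters more. A pyridin-4-yl or a naphthalen-1-yl group at this place would separate the two.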